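From Methyl to Ethoxy on One Measured Compound

The source may hold more compounds than are shown below. What is called first, only, known or untested is meant among the compounds shown, and "the series" means these compounds.

Among the compounds with values here, only one number anchors this comparison in a physicochemical assay for lipophilicity, using the shake flask method, in phosphate buffer, measured as octanol-water partition, with a stated time of 24 h, at pH 7.4, tested at 100 uM; on this read-out lower numbers stand for lower lipophilicity and higher numbers for higher lipophilicity. Within the data shown here, compound 1 (`O=C(O)CS(=O)(=O)c1ccc(OCc2cccc(-c3ccccc3F)c2)cc1`) has the entry "not determined" (no result reported) there, whereas compound 2 (`Cc1ccc(-c2cccc(COc3ccc(S(=O)(=O)CC(=O)O)cc3)c2)c(Cl)c1`) gives 3.05 as the sole measured value, so its standing relative to any other compound cannot be judged. Compound 3 (`CCOc1ccc(-c2cccc(COc3ccc(S(=O)(=O)CC(=O)O)cc3)c2)c(Cl)c1`) has not yet been measured. It differs from compound 2 by a single change (ethoxy in place of methyl on an aromatic carbon) with ethoxy in place of methyl on an aromatic carbon, which turns 2-chloro-4-methylphenyl into 2-chloro-4-ethoxyphenyl. Among the measured compounds shown here, no measured pair shows what this exchange does in this assay, so the data give no direction and no shift beyond the scatter is expected. The estimated step is a number 0.05 log units higher from compound 2 to compound 3 (within the scatter) and remains within that scatter. In this assay compound 3 is estimated at 3.1 with an expected range from 2.7 to 3.5 as the likely span.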

Compound 3, distribution coefficient: 3.12
Compound 3: middle estimate off by 0.02 log units, on the low side; low and high end bracket the measured number.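

In this assay, the exchange of methyl for ethoxy on the aromatic carbon, meta to a chloro group and para to a large group, gives a number 0.07 log units higher from compound 2 to compound 3 (within the scatter). Within the data shown here, this is the first measured pair for the exchange, and it shows that at this position the read-out does not separate 2-chloro-4-methylphenyl from 2-chloro-4-ethoxyphenyl, even though ethoxy brings a hydrogen-bond acceptor that methyl lacks. Nothing available explains why the two compounds read alike.

The compounds shown leave open whether a group of another kind at this position, such as an amine or a carboxylic acid, or a longer chain such as butoxy, would move the read-out beyond the scatter. They also leave open whether the exchange of methyl for ethoxy would give the same result elsewhere on the shared core.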